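The source may report more compounds than this note shows. Statements on the series, on what has been measured and on what is new or still open speak of the compounds shown alone.

Compound 1 `O=C1CC(c2ccccc2)Nc2ccccc21` gives 0.013 ug/mL
Compound 2 `COc1cccc(C2CC(=O)c3ccccc3N2)c1` gives 0.23 ug/mL

In a functional assay on A549 cells (Homo sapiens) for cytotoxicity, read by sulforhodamine B assay (on this read-out lower numbers stand for an effect already at smaller amounts and higher numbers for an effect only at larger amounts of compound), compound 2 holds the higher of the two numbers. Compound 3 `COc1cccc([C@H]2CC(=O)c3ccccc3N2)c1` differs from compound 2 in one respect, the two compounds have the same atoms and bonds; at least one stereo element is drawn with a configuration in one of them and without one in the other: 1 of 1 stereo elements differ; a stereocentre at a saturated ring carbon is drawn without a configuration in compound 2 and R in compound 3 and the atoms and bonds stay the same. Going by the values given here, the only measured step is an 18-fold higher number from compound 1 to compound 2 (1.25 log units; beyond the scatter) and it concerns a methoxy in place of hydrogen, not a stereocentre, so it gives no size for this change. No step beyond the scatter is therefore expected in this assay and neither direction can be ruled out. The expected step is a 1.2-fold lower number from compound 2 to compound 3 (0.06 log units; within the scatter) on this estimate. Compound 3 is expected at 0.2 ug/mL with an estimated range from 0.07 ug/mL to 0.7 ug/mL in this assay.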

Compound 3, concentration for half-maximal effect: 0.5 ug/mL
Compound 3: the middle estimate sits 2.5-fold (0.40 log units) below what was measured, within the range that was stated.
By their numbers in this assay, from the lowest: compound 1; then compound 2; then compound 3.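

In this assay, the stereocentre at a saturated ring carbon makes a visible difference: drawing it as R goes with a 2.2-fold higher number from compound 2 to compound 3 (0.34 log units; beyond the scatter). Going by these compounds alone, the earlier step concerned only a methoxy in place of hydrogen, so this is the first sign that configuration at this carbon counts alongside the groups attached. The comparison needs care, since it does not set two defined configurations against each other: the fact that one of compounds 2 and 3 is drawn with a defined configuration and the other without, at the place where they differ

From the compounds shown here alone, how the S configuration would read remains open. So does how an amine or a carboxylic acid in place of the methoxy would read with the R configuration.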